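Heptyl replaced by 4-fluorophenyl: outlook for compound 3

A few compounds are considered here, and "the series" means these few. Any claim that something is new, unique, unknown or untested is made for them only; others in the source may bear on it.

Compound 1 `CCCCCCCc1cn(C(c2ccccc2)c2cc3cc(Br)ccc3nc2OC)nn1` is the reference of this pair. Among the compounds with values here, in an ADME assay on PC-3 cells (Homo sapiens) for cytotoxicity, read by sulforhodamine B assay, with a stated time of 48 h, tested at 10 uM (on this read-out higher numbers stand for more inhibition at the one concentration tested (going by the name of the read-out) and lower numbers for less inhibition), compound 1 gives 4.42%, the lower of the two numbers measured so far; the nearest is compound 2 `COc1nc2ccc(Br)cc2cc1C(c1ccccc1)n1cc(-c2ccccc2C(F)(F)F)nn1`, which in this assay gives 17.4%. Within the data shown here, the one step measured between compounds that differ in a single place is a number 13 percentage points higher from compound 1 to compound 2 (beyond the scatter), an aromatic group entering where heptyl leaves.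

Compound 3 `COc1nc2ccc(Br)cc2cc1C(c1ccccc1)n1cc(-c2ccc(F)cc2)nn1` has not been measured. It differs from compound 1 by 4-fluorophenyl in place of heptyl on an aromatic carbon. The same kind of change, heptyl giving way to an aromatic ring on the same aromatic carbon, was followed by the modest step from compound 1 to compound 2, so a rise of comparable size is expected here, with the caveat that a single measured step gives no guide to how much the aromatic group itself matters. For compound 3 the expected step is a number 9.6 percentage points higher from compound 1 to compound 3 (within the scatter). The estimate for compound 3 is 14%, within 0% to 30%.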

Compound 3, a percentage reported as inhibition, at one concentration (the size of the read-out at that concentration, not a potency): 16.4%
Beside the measured number, compound 3's estimate is 2.4 percentage points below it; low and high end bracket the measured number.
By their numbers in this assay, from the lowest: compound 1; then compounds 3 and 2 (each within the scatter of the next).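

In this assay, a second aromatic ring in place of heptyl gives a number 12 percentage points higher from compound 1 to compound 3 (beyond the scatter) and thus shows that the rise on this aromatic carbon of the five-membered ring is not confined to the 2-(trifluoromethyl)phenyl of compound 2. Exchanging one substituted phenyl for the other gives a number 1 percentage points lower from compound 2 to compound 3 (within the scatter) and does not separate 4-fluorophenyl from 2-(trifluoromethyl)phenyl in this read-out. No evidence is available to explain the rise from heptyl to either aromatic ring.

From the compounds shown here alone, whether the rise depends on an aromatic ring as such or on the removal of heptyl stays open, and a shorter chain such as propyl at this position would bear on that. Also open, going by these compounds, is how unsubstituted phenyl, or a phenyl ring carrying an amine or a carboxylic acid, would read here.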